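Swapping the aryl group on the oxadiazoline core

This account rests on a few compounds, and the source may have more. Where it says the series, first, only, none or still open, it means among the compounds named here.

Measured so far:
- Compound 1, `COc1cc(C2=NN(C(C)=O)C(c3ccc(F)cc3)O2)cc(OC)c1OC`: 0%
- Compound 2, `COc1cc(C2=NN(C(C)=O)C(c3cc(OC)c(OC)c(OC)c3)O2)cc(OC)c1OC`: -1.8%
- Compound 3, `COc1cccc(/C=N/NC(=O)c2cc(OC)c(OC)c(OC)c2)c1OC`: 53.2%

All three numbers come from a functional assay on PC-3 cells (Homo sapiens) for antiproliferative activity, read by MTT assay, tested at 1 uM; on this read-out lower numbers stand for a weaker effect and higher numbers for a stronger effect at the one concentration tested. Compound 1 is second highest of the three. Its nearest neighbour is compound 2, whose number lies within the scatter of that of compound 1, so the two cannot be told apart. Compound 3, built on a different core, lies far above, beyond the scatter.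

Compound 4, `COc1cc(C2=NN(C(C)=O)C(c3ccc(Cl)c(Cl)c3)O2)cc(OC)c1OC`, shares the core of compound 1 and differs in one place: 3,4-dichlorophenyl in place of 4-fluorophenyl on a saturated ring carbon. For the measured compounds named here, no measured pair shows what this swap does, but compound 1 and compound 2 suggest this core gives little effect in this assay whichever aryl group sits there. In this assay, going by the values given here, no step from compound 1 to compound 4 beyond the scatter is expected; the expected shift is a number 5 percentage points higher from compound 1 to compound 4 (within the scatter). Compound 4 is thus estimated at 5%, in the range -10% to 25%.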

Compound 4, a percentage reported as inhibition, at one concentration (the size of the read-out at that concentration, not a potency): 28.1%
Compound 4: middle estimate off by 23.1 percentage points, on the low side, and the stated range ends below it.
By their numbers in this assay, from the lowest: compounds 2 and 1 (each within the scatter of the next); then compound 4; then compound 3.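

In this assay, 3,4-dichlorophenyl in place of 4-fluorophenyl on the saturated ring carbon gives a number 28.1 percentage points higher from compound 1 to compound 4 (beyond the scatter) and so shows that the shared core can respond to the aryl group at this position. Compound 1 and compound 2 alone gave no sign of this. Nothing available explains the rise. Still open, going by these compounds, is whether a single chlorine, as in 4-chlorophenyl, would give a similar number, or whether both chlorines are needed. Also open, on these data alone, is what an aminophenyl or carboxyphenyl group would do at this position.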